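The source may hold more compounds than are shown below. What is called first, only, known or untested is meant among the compounds shown, and "the series" means these compounds.

Measured compounds in an ADME assay on L6 cells (Rattus norvegicus) for cytotoxicity, read by fluorescence and resazurin assay, with a stated time of 72 h; on this read-out lower numbers stand for an effect already at smaller amounts and higher numbers for an effect only at larger amounts of compound:

Compound 1 `Cc1cc(-c2ccc3[nH]c(=O)nc(-c4ccccc4)c3c2)ccn1` gives > 50000 nM in this assay, a limit of the assay.
Compound 2 `O=c1nc(-c2ccccc2)c2cc(-c3cccnc3)ccc2[nH]1` gives > 50000 nM in this assay, again a limit.
Compound 3 `Cc1cncc(-c2ccc3[nH]c(=O)nc(-c4ccccc4)c3c2)c1` gives > 50000 nM in this assay, also a limit.

Compound 2 stands among three values that are all limits; it sits at the limit of > 50000 nM in this assay, at which 3 of the 3 values shown sit, so it cannot be ranked against compound 1 or compound 3. The step to compound 4 `CN(C)c1ccc(-c2ccc3[nH]c(=O)nc(-c4ccccc4)c3c2)cn1` is dimethylamino in place of hydrogen on an aromatic carbon. The steps among the measured compounds bear on it only indirectly: a step that the two limits leave unreadable from compound 1 to compound 2, a step that the two limits leave unreadable from compound 1 to compound 3 and a step that the two limits leave unreadable from compound 2 to compound 3 are all steps whose sizes the two limits hide. Each change at the same position of the shared core left every compound at the assay limit, so no step beyond the scatter in this assay is expected in either direction for compound 4. Compound 4 is therefore estimated at 60000 nM, with a range from 20000 nM to 200000 nM, which is expected to read as a step that the limit leaves unreadable from compound 2 to compound 4; most likely the assay will again report only a limit for compound 4.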

Compound 4, half-maximal effective concentration: 50000 nM
The estimate for compound 4 lay 1.2-fold (0.08 log units) above the measured number, within the range that was stated.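

Of the four compounds, compound 4 alone returns a number rather than a limit in this assay, which shows that dimethylamino on an aromatic carbon, next to the ring nitrogen and para to a large group, gives a reading the assay can report. The change from hydrogen to dimethylamino reads as a number no higher from compound 2 to compound 4 (the limit leaves the size open). From the compounds shown here alone, its size stays open because compound 2 sits at a limit: the limit of > 50000 nM in this assay, at which 3 of the 4 values shown sit.

Going by these compounds, the steps among compound 1, compound 2 and compound 3 cannot be read either, and whether dimethylamino in place of hydrogen moves the reading beyond the usual scatter remains unknown. Also open, on these data alone, is whether a primary amine, a morpholine or a carboxylic acid at this place would give a lower number than compound 4 does in this assay.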